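Swapping a Methyl for an Amino Group: Expected Lipophilicity

A few compounds are considered here, and "the series" means these few. Any claim that something is new, unique, unknown or untested is made for them only; others in the source may bear on it.

Compound 1 `Cc1c(CN2CCCC2)cc(-c2ccccc2)n1Nc1ccnc2cc(Cl)ccc12`: 3.28
Compound 2 `Cc1c(CN2CCCC2)cc(-c2ccc(F)cc2)n1Nc1ccnc2cc(Cl)ccc12`: 3.45
Compound 3 `Cc1ccc(-c2cc(CN3CCCC3)c(C)n2Nc2ccnc3cc(Cl)ccc23)cc1`: 3.91

Of the compounds shown here, three sharing one core have been measured in a physicochemical assay for lipophilicity, at pH 7.4; a lower number here means a more polar compound, a higher number a more lipophilic compound. Compound 3 gives 3.91, the highest of the three numbers; it differs from the other two only in one group on the phenyl ring. The two steps leading to it are both beyond the scatter: a number 0.63 log units higher from compound 1 to compound 3 (beyond the scatter), and a number 0.46 log units higher from compound 2 to compound 3 (beyond the scatter). The third step, a number 0.17 log units higher from compound 1 to compound 2 (within the scatter), is too small to read as a change.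

Compound 4 `Cc1c(CN2CCCC2)cc(-c2ccc(N)cc2)n1Nc1ccnc2cc(Cl)ccc12` is the next member. It differs from compound 3 by amino in place of methyl on an aromatic carbon. The measured steps bear on this only in part: the step from compound 1 to compound 3 shows what the methyl group added at that place, so taking the methyl away again should at least undo that and bring the number back toward compound 1, which gives 3.28. Going by the values given here, no measured step covers an amino group, so what it adds on its own is not known from these data. The amino group, counted as one donor and one acceptor, is expected to push the number further down than hydrogen would, giving an expected step of a number 1.71 log units lower from compound 3 to compound 4 (beyond the scatter).

Compound 4 is therefore expected to give about 2.2 in this assay, with a likely range from 1.7 to 2.7.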

Compound 4, distribution coefficient: 2.03
Beside the measured number, compound 4's estimate is 0.17 log units above it; the range from low to high includes it.
By their numbers in this assay, from the lowest: compound 4; then compounds 1 and 2 (each within the scatter of the next); then compound 3.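

Going by these compounds alone, until now, changes at this place on the phenyl ring had left the number in this assay level or raised it, and the amino group is the first one here to bring it down, with a number 1.25 log units lower from compound 1 to compound 4 (beyond the scatter) when amino replaces hydrogen. The fall is also clear against the other two groups, with a number 1.42 log units lower from compound 2 to compound 4 (beyond the scatter) when amino replaces fluoro and a number 1.88 log units lower from compound 3 to compound 4 (beyond the scatter) when it replaces methyl, so the choice of group at this place can move the number much further than compounds 1, 2 and 3 alone suggested. Nothing available here accounts for the size of these steps.

The compounds shown leave open whether a hydroxyl, methoxy or dimethylamino group at this same place would bring the number down as far as the amino group does, or whether the fall is particular to amino. They also leave open whether the same swap of methyl for amino would give a step of similar size at another carbon of the phenyl ring or on a different core.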